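Chloro on the benzyl amide ring: expectation for compound 3

A few compounds are considered here, and "the series" means these few. Any claim that something is new, unique, unknown or untested is made for them only; others in the source may bear on it.

For the measured compounds named here, compound 2 `Cc1cc(C(=O)N[C@@H](CC(=O)NCC(C)(C)C)C(=O)N[C@@H](CCc2ccccc2)C(=O)NCc2ccccc2)no1` gives 9 nM in an assay on HEK293 cells for inhibition of nuclear factor NF-kappa-B complex (Homo sapiens), read by a luciferase reporter, with stated times of 1 h and 3 h (a lower number here means a stronger inhibitor, a higher number a weaker inhibitor), the lowest of the two numbers so far. Compound 1 `CC(C)(C)CNC(=O)C[C@H](NC(=O)C(C)(C)C)C(=O)N[C@@H](CCc1ccccc1)C(=O)NCc1ccccc1` gives 62 nM in this assay. Going by the values given here, the single measured step, a 6.9-fold lower number from compound 1 to compound 2 (0.84 log units; beyond the scatter), came from 5-methyl-1,2-oxazol-3-yl in place of tert-butyl on a carbonyl carbon. Compound 3 `Cc1cc(C(=O)N[C@@H](CC(=O)NCC(C)(C)C)C(=O)N[C@@H](CCc2ccccc2)C(=O)NCc2ccccc2Cl)no1` differs from compound 2 by chloro in place of hydrogen on an aromatic carbon, on an aromatic carbon of a six-membered aromatic ring of carbon only, ortho to a large group. Among the compounds with values here, no measured step touches this ring, so there is no guide, and in this assay no shift beyond the scatter is expected, a 1.1-fold higher number from compound 2 to compound 3 (0.05 log units; within the scatter). For compound 3 the estimate is 10 nM, range 3 nM to 35 nM.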

Compound 3, half-maximal inhibitory concentration: 9 nM
The estimate for compound 3 lay 1.1-fold (0.05 log units) above the measured number; the measured number falls inside the stated range.
By their numbers in this assay, from the lowest: compounds 2 and 3 (each within the scatter of the next); then compound 1.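

In this assay, for the compounds shown here, phenyl to 2-chlorophenyl gives no change at the digits printed from compound 2 to compound 3 (within the scatter) and is the first step read on this ring. A chloro ortho to a large group is therefore accepted on the benzyl amide ring, and the number reached with the 5-methyl-1,2-oxazol-3-yl amide is kept. No supporting data bear on why this position responds so little.

From the compounds shown here alone, whether a larger or charged substituent here, such as methoxy, an amine or a carboxylic acid, would be accepted remains open. So does whether chloro behaves the same way in the tert-butyl amide of compound 1.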